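Swapping the Ring on the Thiocarbonyl Carbon

This account rests on a few compounds, and the source may have more. Where it says the series, first, only, none or still open, it means among the compounds named here.

Measured so far:
compound 1 `Nc1ccccc1NC(=O)c1ccc(CSC(=S)N2CCN(Cc3ccccn3)CC2)cc1` — 14.2%
compound 2 `Nc1ccccc1NC(=O)c1ccc(CSC(=S)N2CCN(c3ccc(Cl)cc3)CC2)cc1` — 51.2%
compound 3 `Nc1ccccc1NC(=O)c1ccc(CSC(=S)N2CCCc3ccccc32)cc1` — 26.1%

Of the compounds shown here, three sharing one core have been tested in a functional assay on HeLa cells (Homo sapiens) for antiproliferative activity, read by CCK-8 assay, with a stated time of 72 h, tested at 2 uM; a lower number here means a weaker effect, a higher number a stronger effect of the compound at the concentration tested. Compound 3 stands second highest of the three; its nearest neighbour is compound 1, and the furthest is compound 2, both gaps beyond the scatter. Compound 4 `CC1CCN(C(=S)SCc2ccc(C(=O)Nc3ccccc3N)cc2)CC1` has not yet been measured. It differs from compound 3 in one place: 4-methylpiperidin-1-yl in place of 1,2,3,4-tetrahydroquinolin-1-yl on a thiocarbonyl carbon.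

For the measured compounds named here, only one measured step is available, and it sits elsewhere on the molecule: a number 37 percentage points higher from compound 1 to compound 2 (beyond the scatter), a change on an amine nitrogen in a ring rather than on the thiocarbonyl carbon. It shows that the group attached at that end of the core can move the read-out strongly, but it does not show which way a saturated ring in place of a bicyclic one will go. With no direct comparison, compound 4 is expected to land near compound 3, with a modest downward lean, as a step of a number 4.1 percentage points lower from compound 3 to compound 4 (within the scatter) that may well fall inside the scatter. Compound 4 is therefore estimated at 22%, with a range from 8% to 40%.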

Compound 4, a percentage reported as inhibition, at one concentration (the size of the read-out at that concentration, not a potency): 46.8%
Compound 4: middle estimate off by 24.8 percentage points, on the low side, and the stated range ends below it.
By their numbers in this assay, from the lowest: compound 1; then compound 3; then compounds 4 and 2 (each within the scatter of the next).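

In this assay, placing 4-methylpiperidin-1-yl instead of 1,2,3,4-tetrahydroquinolin-1-yl on the thiocarbonyl carbon gives a number 20.7 percentage points higher from compound 3 to compound 4 (beyond the scatter), the only step shown that was taken at this position. It shows that the group on this carbon can itself move the read-out beyond the scatter, and that, in this pair, the group without an aromatic ring and with fewer heavy atoms gives the higher number, so the aromatic ring of 1,2,3,4-tetrahydroquinolin-1-yl is not needed for a read-out of this size. No measurement at hand accounts for the direction or the size of this step.

The compounds shown leave open which part of the change carries the step: the loss of the aromatic ring and the arrival of the methyl group come together here, and an unsubstituted piperidine or a morpholine on the same carbon would begin to pull these apart. A read-out at one concentration also leaves the potency of compound 3 and compound 4 open, so it remains unclear how far this step would hold across a range of concentrations.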